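The source may report more compounds than this note shows. Statements on the series, on what has been measured and on what is new or still open speak of the compounds shown alone.

Compound 1 `COc1cccc(/C=C/C(=O)c2ccc(OC)c3c2OC(C)(C)C=C3)c1`, compound 2 `COc1ccc(C(=O)/C=C/c2cc(OC)c(OC)c(OC)c2)c2c1C=CC(C)(C)O2` and compound 3 `COc1ccc(C(=O)/C=C/c2cccc(O)c2)c2c1C=CC(C)(C)O2` share one core and have each been tested in a functional assay on K562 cells (Homo sapiens) for antiproliferative activity, read by MTT assay, with a stated time of 24 h; a lower number here means a stronger inhibitor, a higher number a weaker inhibitor. In this assay compound 1 reaches only the limit of the measurement, > 10000 nM. Compound 2 likewise gives no number but a limit, > 10000 nM. Compound 3 too stops at a limit, > 10000 nM. Compound 3 differs from compound 1 by hydrogen in place of methyl on an oxygen on an aromatic ring; the size of that step, a step that the two limits leave unreadable from compound 1 to compound 3, cannot be read, because of the limit of > 10000 nM in this assay, at which 3 of the 3 values shown sit. How compound 2 differs from compound 1 is not broken down here. Compound 4 `COc1cc(/C=C/C(=O)c2ccc(OC)c3c2OC(C)(C)C=C3)cc(OC)c1O` remains to be measured in this assay. It stands to compound 2 as compound 3 stands to compound 1, carrying hydrogen in place of methyl on an oxygen on an aromatic ring at a place described in the same words, so this is the same change. Among the compounds with values here, since every value known so far is a limit, the change expected from compound 2 to compound 4 is a step that the limit leaves unreadable from compound 2 to compound 4, an expectation resting on no readable step at all. Compound 4 is therefore expected to remain weak, with an estimate of 20000 nM, most likely again reported only as a limit.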

Compound 4, half-maximal inhibitory concentration: > 10000 nM
Compound 4 gave a limit, no number; the forecaster's own chance of this, stated with the estimate: 75%; the middle value lies beyond the limit too.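

The step from compound 2 to compound 4, like the one from compound 1 to compound 3, has no readable size, because neither compared compound gives a number: the limit of > 10000 nM in this assay, at which 4 of the 4 values shown sit.

The compounds shown leave open whether replacing methoxy with hydroxy changes the activity in this assay at all, and what change to the shared core would give a measurable value.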